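Swapping Nitro for a Selenium Group: Compound 4 Ahead

A few compounds are considered here, and "the series" means these few. Any claim that something is new, unique, unknown or untested is made for them only; others in the source may bear on it.

Three compounds have been measured in a functional assay on MHCC97H cells (Homo sapiens) for antiproliferative activity, read by MTT assay, with a stated time of 48 h; on this read-out lower numbers stand for stronger inhibition and higher numbers for weaker inhibition:
Compound 1, `COc1cc(C(=O)/C=C/c2cn(C)c3ccccc23)cc(N)c1OC`, gives 289 nM.
Compound 2, `COc1ccc2c(/C=C/C(=O)c3cc(OC)c(OC)c([N+](=O)[O-])c3)cn(C)c2c1`, gives 562 nM.
Compound 3, `COc1ccc2c(/C=C/C(=O)c3cc(OC)c(OC)c([N+](=O)[O-])c3)c[nH]c2c1`, gives 289 nM.

Compound 3 stands level with compound 1 at the digits shown, and these two together hold the lowest numbers of the three. Its furthest neighbour is compound 2, yet even that gap stays inside the usual scatter: a 1.9-fold lower number from compound 2 to compound 3 (0.29 log units; within the scatter).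

Compound 4, `COc1ccc2c(/C=C/C(=O)c3cc(OC)c(OC)c([Se]C)c3)c[nH]c2c1`, is the next candidate. It differs from compound 3 in one place: a group of 2 heavy atoms (1 carbon, 1 selenium; no ring) in place of a group of 3 heavy atoms (1 nitrogen, 2 oxygen; no ring), on an aromatic carbon.

Among the measured compounds shown here, no measured step touches this kind of exchange. For the measured compounds named here, the only single step available, from compound 2 to compound 3, concerns the hydrogen in place of methyl on an aromatic nitrogen and lay within the scatter. Compound 1 carries an amino group where compound 3 carries nitro, but it also differs elsewhere, so all that can be said is that compound 1 and compound 3 show level values. With nothing bearing on the nitro-to-selenium change, no step beyond the scatter is expected in this assay, though the uncertainty is wide. Compound 4 is therefore estimated at 300 nM, in a range from 90 nM to 1000 nM, which means an expected step of a 1.0-fold higher number from compound 3 to compound 4 (0.02 log units; within the scatter).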

Compound 4, half-maximal inhibitory concentration: 58 nM
The estimate for compound 4 lay 5.2-fold (0.71 log units) above the measured number, outside the stated range (below it).
By their numbers in this assay, from the lowest: compound 4; then compounds 1, 3 and 2 (each within the scatter of the next).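

This exchange shows that the aromatic carbon carrying the nitro group, ortho to a methoxy group, is a place where a single change can move the result beyond the scatter: in this assay, the group of 2 heavy atoms (1 carbon, 1 selenium; no ring) gives a 5.0-fold lower number from compound 3 to compound 4 (0.70 log units; beyond the scatter). Among the compounds shown here, until now, the only single-place step, the hydrogen in place of methyl on an aromatic nitrogen, had stayed within the scatter, so this is the first clear sign of a structural change affecting the number. The nitro group leaves with its 2 hydrogen-bond acceptors and its double bond, while the entering group has 0 hydrogen-bond acceptors, but nothing here measures why the number fell or which of these differences matters.

The compounds shown leave open whether selenium itself is needed, a question that a methylthio group, with sulfur in selenium's place, or a longer chain on the selenium could address. On these data alone, it also remains open whether the same exchange would give a similar step with methyl on the aromatic nitrogen, as in compound 2.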